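Cytotoxicity of benzyl-substituted cyclic sulfamide ureas in MT4 cells

This account rests on a few compounds, and the source may have more. Where it says the series, first, only, none or still open, it means among the compounds named here.

Measured so far:
compound 1 `O=C1N(Cc2ccccc2Br)c2cccn2S(=O)(=O)N1Cc1cccc(F)c1` > 269000 nM
compound 2 `N#Cc1cccc(CN2C(=O)N(Cc3ccccc3)S(=O)(=O)n3cccc32)c1` > 318000 nM

In an ADME assay on MT4 cells (Homo sapiens) for cytotoxicity, read by MTT assay, with a stated time of 5 days (a higher number here means that more compound is tolerated, a lower number that less compound is tolerated), compound 1 gives > 269000 nM, which is a limit of the assay rather than a number. Compound 2 likewise reaches only a limit, > 318000 nM. Both values stand at the top of what this assay reports the limit of > 269000 nM in this assay, at which 1 of the 2 values shown sits (the limit of > 318000 nM in this assay, at which 1 of the 2 values shown sits), so no ordering of the two compounds can be drawn from them.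

Compound 3 `O=C1N(Cc2ccccc2Cl)c2cccn2S(=O)(=O)N1Cc1ccccc1` has not been measured. It differs from compound 2 in one place: 2-chlorophenyl in place of 3-cyanophenyl on a saturated chain carbon bound to an amide-type nitrogen in a ring. For the measured compounds named here, since compound 2 sits at a limit, no step of measurable size can be read off for this change; the expectation is no step beyond the scatter.

Compound 3 is expected to give 300000 nM in this assay, within 100000 nM to 1000000 nM, with the step from compound 2 to compound 3 estimated as an at least 1.0-fold lower number from compound 2 to compound 3 (0.02 log units; that floor lies within the scatter), most likely reported again as a limit.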

Compound 3, half-maximal cytotoxic concentration: > 291000 nM
Compound 3 gave a limit, no number; the forecaster's own chance of this, stated with the estimate: 80%; the middle value does not contradict the limit.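

In this assay compound 3 gives > 291000 nM, a limit and not a number. Compound 2 also stands at a limit, so no step can be read between compound 2 and compound 3. The compounds shown leave open what concentration any of them tolerates in these cells.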